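Adding a Methyl Group to a Phenyl Ring

The compounds below may be only part of what the source reports. "The series", "measured", "known", "first", "only" and "open" are said of these compounds alone.

Compound 1 `CC1(C)[C@H]2CC[C@]1(C)N(Cc1cn(-c3cccc(F)c3)nn1)C(=O)C2` gives 80 nM
Compound 2 `CC1(C)[C@H]2CC[C@]1(C)N(Cc1cn(-c3ccccc3Cl)nn1)C(=O)C2` gives 60 nM
Compound 3 `CC1(C)[C@H]2CC[C@]1(C)N(Cc1cn(-c3ccccc3)nn1)C(=O)C2` gives 90 nM

All three values come from a functional assay on HepG2 cells (Homo sapiens) for inhibition, read by MTT assay, with a stated time of 24 h (on this read-out lower numbers stand for stronger inhibition and higher numbers for weaker inhibition), and no order can be drawn among them. Compound 3 gives 90 nM and stands level with the other two: the steps leading to it (a 1.1-fold higher number from compound 1 to compound 3 (0.05 log units; within the scatter) and a 1.5-fold higher number from compound 2 to compound 3 (0.18 log units; within the scatter)) both lie within the scatter.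

Compound 4 `Cc1ccc(-n2cc(CN3C(=O)C[C@@H]4CC[C@@]3(C)C4(C)C)nn2)cc1` differs from compound 3 by a single change, methyl in place of hydrogen on an aromatic carbon of the phenyl ring. Among the compounds with values here, no measured compound carries a methyl group on this ring, so the nearest guides are the two steps above, which swap fluoro or chloro for hydrogen on the same ring. Neither step moved the number beyond the scatter, and the step between the two substituted compounds (a 1.3-fold lower number from compound 1 to compound 2 (0.12 log units; within the scatter)) stayed within it too.

A step beyond the scatter is therefore not expected in this assay, and the data favour no clear direction. The expected change (a 1.1-fold lower number from compound 3 to compound 4 (0.05 log units; within the scatter)) stays small. The estimate for compound 4 is 80 nM with an expected range running from 40 nM up to 160 nM in repeated measurements.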

Compound 4, half-maximal inhibitory concentration: 480 nM
Compound 4: the middle estimate sits 6.0-fold (0.78 log units) below what was measured; measured number above the stated range.
By their numbers in this assay, from the lowest: compounds 2, 1 and 3 (each within the scatter of the next); then compound 4.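

In this assay, within the data shown here, methyl is the first change on this ring to carry the number beyond the scatter: a 5.3-fold higher number from compound 3 to compound 4 (0.73 log units; beyond the scatter), with the methyl on an aromatic carbon para to a large group, and this higher number means weaker inhibition. The comparisons with the halogen-bearing compounds point the same way, with an 8.0-fold higher number from compound 2 to compound 4 (0.90 log units; beyond the scatter) and a 6.0-fold higher number from compound 1 to compound 4 (0.78 log units; beyond the scatter), so compound 4 is the weakest of the four, and the ring that gave closely matching numbers as phenyl, 3-fluorophenyl and 2-chlorophenyl does not accept every substituent equally. Nothing measured here shows why adding this small group has such an effect.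

The compounds shown leave open whether this drop in inhibition is specific to methyl or would also follow from another group at this same place, such as fluoro, chloro, methoxy or an amine. They also leave open how a methyl group would behave elsewhere on the ring, and whether a longer chain such as ethyl at this place would weaken inhibition further.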